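From 3-aminophenyl to 4-chlorophenyl on the shared core

The source may hold more compounds than are shown below. What is called first, only, known or untested is meant among the compounds shown, and "the series" means these compounds.

Measured in a functional assay on SGC-7901 cells (Homo sapiens) for antiproliferative activity, read by MTT assay, with a stated time of 72 h; a higher number here means a weaker inhibitor, a lower number a stronger inhibitor:
Compound 1 `CCOc1ccc(-c2ccc3ncn(-c4cc(OC)c(OC)c(OC)c4)c3c2)cc1`: 2970 nM
Compound 2 `COc1cc(-n2cnc3ccc(-c4cccc(N)c4)cc32)cc(OC)c1OC`: 21 nM

Compound 2 holds the lower of the two numbers in this assay, and its gap to compound 1 lies beyond the scatter. Compound 3 `COc1cc(-n2cnc3ccc(-c4ccc(Cl)cc4)cc32)cc(OC)c1OC` keeps the shared core and changes one group, with 4-chlorophenyl in place of 3-aminophenyl on an aromatic carbon. Among the compounds with values here, only one measured step bears on this change. That large step, a 140-fold lower number from compound 1 to compound 2 (2.15 log units; beyond the scatter), came with 3-aminophenyl in place of 4-ethoxyphenyl. Within the data shown here, compound 3 gives up the same 3-aminophenyl group, so a sizeable move to a higher number is expected, though no measured compound carries 4-chlorophenyl. The estimated change is a 24-fold higher number from compound 2 to compound 3 (1.38 log units; beyond the scatter), probably smaller than the measured step. For compound 3 the expected value is 500 nM, with an estimated range from 90 nM to 3000 nM.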

Compound 3, half-maximal inhibitory concentration: 1270 nM
Beside the measured number, compound 3's estimate is 2.5-fold (0.40 log units) below it, and the stated range covers the measured number.
By their numbers in this assay, from the lowest: compound 2; then compound 3; then compound 1.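

In this assay, a second group replacing 3-aminophenyl also brings a large loss, with a 60-fold higher number from compound 2 to compound 3 (1.78 log units; beyond the scatter) to set beside the earlier step from 4-ethoxyphenyl, so the low number of compound 2 is not tied to a comparison with one partner alone. The two groups that lack the amine lie much closer together, and a 2.3-fold lower number from compound 1 to compound 3 (0.37 log units; beyond the scatter) is only a modest step, although it lies beyond the scatter. Nothing at hand gives a measured reason for either step.

The compounds shown leave open whether the amine itself or its place on the phenyl ring matters, as 3-aminophenyl differs from both other groups in substituent and in position. A 4-aminophenyl or 3-chlorophenyl group at this position would separate those two changes.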